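Replacing nitro with methyl on the biaryl ortho substituent

The source may report more compounds than this note shows. Statements on the series, on what has been measured and on what is new or still open speak of the compounds shown alone.

Measured so far:
compound 1, `CC(Oc1ccccc1-c1cccnc1)C1=NCCN1`: 0.5
compound 2, `CC(Oc1ccccc1-c1ccncc1)C1=NCCN1`: < 0.3
compound 3, `CC(Oc1ccccc1-c1ccccc1[N+](=O)[O-])C1=NCCN1`: < 0.3

In a functional assay on CHO cells for agonist activity at Alpha-2B adrenergic receptor (Homo sapiens) (a higher number here means a larger maximal response, a lower number a smaller maximal response), compound 1 gives 0.5. For compound 2 this assay reports only a limit, < 0.3. The change from compound 1 to compound 2 is a number at least 0.20 lower from compound 1 to compound 2 (beyond the scatter). Compound 3 also sits at a limit of this assay, < 0.3, which is the limit of < 0.3 in this assay, at which 2 of the 3 values shown sit.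

Compound 4, `Cc1ccccc1-c1ccccc1OC(C)C1=NCCN1`, differs from compound 3 by methyl in place of nitro on an aromatic carbon. Within the data shown here, no measured step concerns this position, since the only measured step, the one from compound 1 to compound 2, concerns the pyridinyl ring. With compound 3 at the lower limit, any change can only be upward or none. Compound 4 is therefore estimated at 0.3, between 0.15 and 0.55, a step of a number no lower from compound 3 to compound 4 (the limit leaves the size open) expected.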

Compound 4, intrinsic activity: the largest response reached, as a fraction of the reference agonist's: < 0.3
Compound 4: only a limit was reported; the forecaster's own chance of this, stated with the estimate: 50%; the middle value sits exactly at the limit.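

In this assay compound 4 is reported only as a limit, < 0.3, so the steps linking compound 4 to compound 2 and compound 3 cannot be read. With 2-methylphenyl in place of pyridin-3-yl, the result is a number at least 0.20 lower from compound 1 to compound 4 (beyond the scatter). Methyl, like nitro, leaves this biaryl series at the same limit: the limit of < 0.3 in this assay, at which 3 of the 4 values shown sit.

The compounds shown leave open whether compound 3 and compound 4 differ at all. They also leave open whether another group on this aromatic carbon, such as an amine or a hydroxyl, would give a response above that limit.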